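The compounds below may be only part of what the source reports. "The series", "measured", "known", "first", "only" and "open" are said of these compounds alone.

Series notes. Compound 1 `C#CCN(C)CCCOc1ccc2ccc(=O)oc2c1` is the smallest member of the set; in an assay on isolated protein for inhibition of Amine oxidase [flavin-containing] B (Homo sapiens), read by fluorescence and Amplex Red, with stated times of 15 min and 20 min (a higher number here means a weaker inhibitor, a lower number a stronger inhibitor), compound 1 gives 1090 nM. Compound 2 `C#CCN(CCCOc1ccc2ccc(=O)oc2c1)Cc1ccc(F)c(F)c1` gives 4860 nM, and compound 3 `C#CCN(CCCOc1ccc2ccc(=O)oc2c1)Cc1ccccc1` gives 3740 nM. On these numbers compound 3 stands second highest of the three: a 3.4-fold higher number from compound 1 to compound 3 (0.54 log units; beyond the scatter), while a 1.3-fold lower number from compound 2 to compound 3 (0.11 log units; within the scatter). Compound 4 `C#CCN(CCCOc1ccc2ccc(=O)oc2c1)Cc1cccc(F)c1` differs from compound 3 by fluoro in place of hydrogen on an aromatic carbon. Going by the values given here, the one measured step that bears on this change is a 1.3-fold lower number from compound 2 to compound 3 (0.11 log units; within the scatter), where taking away both fluorines on the benzyl group moved the number by nothing beyond the scatter. The larger moves, a 4.5-fold higher number from compound 1 to compound 2 (0.65 log units; beyond the scatter) and a 3.4-fold higher number from compound 1 to compound 3 (0.54 log units; beyond the scatter), concern the whole benzyl group rather than a fluorine on it, so they do not speak to a single fluoro placed meta to a large group. In this assay the step from compound 3 to compound 4 is therefore expected to be a 1.1-fold higher number from compound 3 to compound 4 (0.03 log units; within the scatter), nothing beyond the scatter. Compound 4 is expected to give 4000 nM, within 2000 nM to 8000 nM.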

Compound 4, half-maximal inhibitory concentration: 4440 nM
Compound 4: middle estimate off by 1.1-fold (0.05 log units), on the low side; low and high end bracket the measured number.
By their numbers in this assay, from the lowest: compound 1; then compounds 3, 4 and 2 (each within the scatter of the next).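

In this assay a single fluoro on the benzyl group can now be read on its own: a 1.2-fold higher number from compound 3 to compound 4 (0.07 log units; within the scatter), so benzyl and 3-fluorobenzyl are not told apart at this position. The second fluorine adds nothing readable either, with a 1.1-fold lower number from compound 2 to compound 4 (0.04 log units; within the scatter), so none, one or two fluorines on this ring give numbers within the scatter across compound 3, compound 4 and compound 2. The gap to the smallest member remains with this ring too, at a 4.1-fold higher number from compound 1 to compound 4 (0.61 log units; beyond the scatter), so among these compounds it follows the benzyl group and not its fluorine count, and nothing measured here accounts for that.

Going by these compounds, whether methoxy, nitrile or a carboxylic acid on this ring would move the number beyond the scatter stays open. So does the effect of a longer chain joining the amine nitrogen to the shared core.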